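Single-Concentration Notes on an Amide Variation

The source may report more compounds than this note shows. Statements on the series, on what has been measured and on what is new or still open speak of the compounds shown alone.

Compound 1 `CCOC(=O)/C=C/c1ccncc1-c1ccc2[nH]ccc2c1`, compound 2 `NC(=O)/C=C/c1ccncc1-c1ccc2ccccc2c1` and compound 3 `COC1CN(C(=O)/C=C/c2ccncc2-c2ccc3[nH]ncc3c2)C1` have each been run in an assay on a protein complex for inhibition of CDK8/Cyclin C (Homo sapiens), with a stated time of 1 h, tested at 10 uM; a lower number here means less inhibition, a higher number more inhibition at the concentration tested (going by the name of the read-out). Compound 1 gives 100%, compound 2 gives 102% and compound 3 gives 98%. Compound 2 holds the highest number of the three, yet its gap to compound 1 and its gap to compound 3 both lie within the usual scatter, so the three are best read as one level with no ranking among them.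

Compound 4 `COC1CN(C(=O)/C=C/c2ccncc2-c2ccc3ccccc3c2)C1` has not yet been measured. Relative to compound 2 it carries 3-methoxyazetidin-1-yl in place of amino on a carbonyl carbon. Compound 3 already bears this same entering group on its carbonyl carbon and gives 98%, a number that sits alongside compound 1 and compound 2.

Because compound 3 gives 98% with the entering group in place, compound 4 is expected to show no step beyond the scatter, the expected step being a number 3 percentage points lower from compound 2 to compound 4 (within the scatter). The estimate for compound 4 is 99%, with a range from 90% to 105%.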

Compound 4, a percentage reported as inhibition, at one concentration (the size of the read-out at that concentration, not a potency): 100%
For compound 4 the middle estimate is 1 percentage points below the measured one; the range from low to high includes it.
By their numbers in this assay, from the lowest: compounds 3, 1, 4 and 2 (each within the scatter of the next).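

In this assay, among these compounds, the change to 3-methoxyazetidin-1-yl in place of amino on a carbonyl carbon gives a number 2 percentage points lower from compound 2 to compound 4 (within the scatter) and is the only step here read between compounds that differ in one place. On the core of compound 2, this position therefore accepts the larger ring-bearing group with no step beyond the scatter, although the read-out gives the size of inhibition at one concentration and says nothing of potency. Nothing measured here explains why the number holds at this level.

Still open, as far as these compounds go, is whether a carboxylic acid or a dimethylamino group on the same carbonyl carbon would stay at this level. Also open, from the compounds shown here alone, is whether a full concentration series would separate compound 2 from compound 4.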